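The compounds below may be only part of what the source reports. "The series", "measured", "known", "first", "only" and "open" are said of these compounds alone.

Measured so far:
compound 1 `NCc1cc(Oc2cccc(C(=O)NCCS(N)(=O)=O)c2)nc(C(F)(F)F)c1` — 540 nM
compound 2 `NCc1cc(Oc2cccc(C(=O)N3CC[C@@H](N)C3)c2)nc(C(F)(F)F)c1` — 1230 nM
compound 3 `NCc1cc(Oc2cccc(C(=O)NCc3cc4ccccc4s3)c2)nc(C(F)(F)F)c1` — "not determined" (no result reported) in an ADME assay on the whole organism (lung, Mus musculus) for pharmacokinetics, read by LC-MS, at a dose of 30 mg/kg by the oral route; on this read-out higher numbers stand for higher exposure at the dose given and lower numbers for lower exposure

All three compounds share one core and differ only in the group on the amide. Compound 3 has no number in this assay, so there is nothing to place it against compounds 1 and 2. Compound 4 `NCc1cc(Oc2cccc(C(=O)NCCn3cnnn3)c2)nc(C(F)(F)F)c1` is the next one to be tested. The change from compound 3 is (1H-tetrazol-1-yl)methyl in place of 1-benzothiophen-2-yl on a saturated chain carbon bound to an amide-type nitrogen. Among the measured compounds shown here, the only measured step that also alters the amide substituent is a 2.3-fold higher number from compound 1 to compound 2 (0.36 log units; beyond the scatter), a modest move between the (2-sulfamoylethyl)amino group and the 3-aminopyrrolidin-1-yl group. With no value for compound 3, the step to compound 4 cannot be sized, and the estimate rests on compounds 1 and 2 alone. Compound 4 is therefore expected to reach roughly 700 nM, with a range of 200 nM to 2500 nM.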

Compound 4, maximal plasma concentration: 3460 nM
Beside the measured number, compound 4's estimate is 4.9-fold (0.69 log units) below it; measured number above the stated range.
By their numbers in this assay, from the lowest: compound 1; then compound 2; then compound 4.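

In this assay the 2-(1H-tetrazol-1-yl)ethyl group gives the highest number among the measured compounds, with a 2.8-fold higher number from compound 2 to compound 4 (0.45 log units; beyond the scatter) and a 6.4-fold higher number from compound 1 to compound 4 (0.81 log units; beyond the scatter). The second step is the simpler comparison: the chain stays the same and only sulfamoyl gives way to 1H-tetrazol-1-yl, so the group carried by this chain alone can shift the number. No measurement shown explains this rise. Still open, as far as these compounds go, is whether a carboxylic acid on the same chain, or a longer chain carrying 1H-tetrazol-1-yl, would match it.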